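Replacing the halogenated ring of compound 3 with a hydroxylated methylphenyl

A few compounds are considered here, and "the series" means these few. Any claim that something is new, unique, unknown or untested is made for them only; others in the source may bear on it.

Of the compounds shown here, three sharing one core have been measured in a functional assay on HEK293 cells with D(4) dopamine receptor (Homo sapiens) as the target, read by FLIPR; a higher number here means that more compound is needed for the effect, a lower number that less compound is needed. Compound 3 `O/N=C(\CCN1CCN(c2ccccn2)CC1)c1ccc(Cl)cc1` gives 475 nM, the highest number of the three. Compound 2 `O/N=C(\CCN1CCN(c2ccccn2)CC1)c1ccc(F)cc1` gives 31 nM, and compound 1 `Cc1cccc(/C(CCN2CCN(c3ccccn3)CC2)=N/O)c1` gives 2.3 nM. The steps between them are all large: a 13-fold higher number from compound 1 to compound 2 (1.13 log units; beyond the scatter), a 15-fold higher number from compound 2 to compound 3 (1.19 log units; beyond the scatter), and a 210-fold higher number from compound 1 to compound 3 (2.31 log units; beyond the scatter). So compound 3 stands at the weak end, far from compound 1.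

Compound 4 `Cc1ccc(O)c(/C(CCN2CCN(c3ccccn3)CC2)=N/O)c1` has not yet been measured. It differs from compound 3 in one place: 2-hydroxy-5-methylphenyl in place of 4-chlorophenyl on a carbon with a double bond to nitrogen. Among the compounds with values here, the entering group again carries a methyl on the phenyl ring, as the 3-methylphenyl of compound 1 does, and adds a hydroxyl that no measured compound has. The step that bears most directly is a 210-fold higher number from compound 1 to compound 3 (2.31 log units; beyond the scatter), which shows that a methylphenyl gave a far lower number than the chlorophenyl. Within the data shown here, no measured step tells what the hydroxyl adds or takes away. Because compound 1 gives 2.3 nM, a large drop toward that value is expected, with the unknown hydroxyl widening the range. The expected step is a 59-fold lower number from compound 3 to compound 4 (1.77 log units; beyond the scatter). For compound 4 in this assay the estimate is 8 nM, within 1.5 nM to 50 nM.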

Compound 4, half-maximal effective concentration: 19.2 nM
For compound 4 the middle estimate is 2.4-fold (0.38 log units) below the measured one; the measured number falls inside the stated range.
By their numbers in this assay, from the lowest: compound 1; then compounds 4 and 2 (each within the scatter of the next); then compound 3.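

In this assay, within the data shown here, the new result gives the first direct reading of what a hydroxy group does on this ring: an 8.3-fold higher number from compound 1 to compound 4 (0.92 log units; beyond the scatter), a modest step in which hydroxy stands in place of hydrogen on an aromatic carbon and nothing else changes. The hydroxy group therefore raises the number on the methyl-bearing ring, yet the replacement of 4-chlorophenyl by 2-hydroxy-5-methylphenyl still gives a large fall, a 25-fold lower number from compound 3 to compound 4 (1.39 log units; beyond the scatter), so a ring with a hydroxy group can sit on the carbon with a double bond to nitrogen and remain far from the high end of this small set. The comparison with the 4-fluorophenyl ring shows a 1.6-fold lower number from compound 2 to compound 4 (0.21 log units; within the scatter), which lies within the scatter, so these two quite different rings cannot be told apart in this assay.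

No available measurement explains why any of these steps has the size it does. Also open, as far as these compounds go, is whether a methoxy group or an amine in place of the hydroxy would give a similar step, and whether the hydroxy group would have the same effect on a phenyl ring carrying no methyl.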